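Coumarin core: methyl in place of ethoxy toward weak binding

This account rests on a few compounds, and the source may have more. Where it says the series, first, only, none or still open, it means among the compounds named here.

Measured compounds:
compound 1, `CCOc1cccc2cc(-c3cc(OC)c(OC)c(OC)c3)c(=O)oc12`, 9050 nM in an assay on CHO cells for displacement of a labelled ligand from adenosine receptor A3 (Homo sapiens), read by radioligand binding; a lower number here means a stronger inhibitor, a higher number a weaker inhibitor
compound 2, `Cc1ccc(-c2cc3cccc(C)c3oc2=O)cc1`, 16600 nM

Compound 1 holds the lowest of the two numbers, and compound 2 sits within the scatter of it, so the two are not told apart. Compound 3, `COc1cc(-c2cc3cccc(C)c3oc2=O)cc(OC)c1OC`, differs from compound 1 by methyl in place of ethoxy on an aromatic carbon. For the measured compounds named here, no measured pair shows this change, so the step from compound 1 to compound 3 is expected to be small, with no clear direction beyond the scatter, as a 1.3-fold higher number from compound 1 to compound 3 (0.12 log units; within the scatter). Compound 3 is therefore estimated at 12000 nM, with a range from 3000 nM to 45000 nM.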

Compound 3, inhibition constant: 9820 nM
Compound 3: the middle estimate sits 1.2-fold (0.09 log units) above what was measured; the measured number falls inside the stated range.
By their numbers in this assay, from the lowest: compounds 1, 3 and 2 (each within the scatter of the next).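

In this assay, for the compounds shown here, the step (a 1.1-fold higher number from compound 1 to compound 3 (0.04 log units; within the scatter)) is the first direct reading of methyl in place of ethoxy on this aromatic carbon, ortho to a fused ring. It lies within the scatter, so ethoxy and methyl are not told apart at this place, and the oxygen of ethoxy makes no difference that can be read. No measurement at hand bears on the reason for this result.

From the compounds shown here alone, whether an amine or a longer chain at this place would shift the number beyond the scatter stays open. So does whether this change reads the same in compounds without the methoxy groups of compound 1.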